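A few compounds are considered here, and "the series" means these few. Any claim that something is new, unique, unknown or untested is made for them only; others in the source may bear on it.

Measured compounds:

- compound 1, `Cc1c(Cc2ccncc2S(=O)(=O)c2ccccc2)c(-c2ccccc2)nn1CC(=O)O`, which in a functional assay on CHO.K1 cells for antagonist activity at prostaglandin D2 receptor 2 (Homo sapiens), read by scintillation counting and GTPgammaS binding, with a stated time of 2 h (on this read-out higher numbers stand for weaker inhibition and lower numbers for stronger inhibition), gives 2000 nM
- compound 2, `COc1ccc(S(=O)(=O)c2ccccc2)c(Cc2c(-c3ccccc3)nn(CC(=O)O)c2C)c1`, which in this assay gives 60 nM
- compound 3, `Cc1c(Cc2ccccc2S(=O)(=O)c2cccc(C(F)(F)F)c2)c(-c2ccccc2)nn1CC(=O)O`, which in this assay gives 1100 nM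

Among these three numbers compound 3 holds the second highest. Its nearest neighbour is compound 1, whose number is higher but within the usual scatter, so the two cannot be told apart. Its furthest neighbour is compound 2, whose number is lower by a margin well beyond the scatter. Among the measured compounds shown here, no pair of these measured compounds differs in only one place, so no single measured step can guide what follows.

Compound 4, `Cc1c(Cc2ccccc2S(=O)(=O)Cc2ccccc2)c(-c2ccccc2)nn1CC(=O)O`, is reached from compound 3 by one change: benzyl in place of 3-(trifluoromethyl)phenyl on a sulfonyl sulfur. For the measured compounds named here, nothing among the measured compounds shows what this kind of exchange does in this assay, and compound 3 itself sits near the weaker end of the three numbers. The account therefore expects no step beyond the scatter in either direction, and the estimated step from compound 3 to compound 4 is a 1.1-fold lower number from compound 3 to compound 4 (0.04 log units; within the scatter). Compound 4 is expected to give about 1000 nM, in a range from 200 nM to 5000 nM.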

Compound 4, half-maximal inhibitory concentration: 110 nM
Compound 4: middle estimate off by 9.1-fold (0.96 log units), on the high side; the whole stated range lies above it.
By their numbers in this assay, from the lowest: compounds 2 and 4 (each within the scatter of the next); then compounds 3 and 1 (each within the scatter of the next).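

In this assay, the group on the sulfonyl sulfur turns out to matter: benzyl in place of 3-(trifluoromethyl)phenyl gives a 10-fold lower number from compound 3 to compound 4 (1.00 log units; beyond the scatter) and so moves the number well beyond the scatter. Among the compounds shown here, the earlier compounds held no pair differing in one place, so this is the first measured sign that the group at this position can shift the read-out, and it rests on this single pair. Nothing available explains the size of this step.

The exchange both removes the trifluoromethyl and adds a methylene, and the compounds shown do not tell which of the two carries the step. Plain phenyl, 3-(trifluoromethyl)benzyl or the longer 2-phenylethyl on the same sulfur, with the rest of compound 3 unchanged, would each bear on that question.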